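Acetyl in place of cyano on the chain

This account rests on a few compounds, and the source may have more. Where it says the series, first, only, none or still open, it means among the compounds named here.

In a functional assay on HeLa cells (Homo sapiens) for inhibition (a higher number here means a weaker inhibitor, a lower number a stronger inhibitor), compound 1 `Cc1cn(/C=C/C=O)c(=O)[nH]c1=O` gives 100000 nM. Compound 2 `Cc1cn(/C=C/C#N)c(=O)[nH]c1=O` is reported only as a limit, > 100000 nM. This is the limit of > 100000 nM in this assay, at which 1 of the 2 values shown sits, so compound 2 has no readable number of its own. Compound 3 `CC(=O)/C=C/n1cc(C)c(=O)[nH]c1=O` differs from compound 2 by acetyl in place of cyano on a double-bonded chain carbon bound to a double-bonded chain carbon, which puts acetyl in place of cyano on a double-bonded chain carbon bound to a double-bonded chain carbon. Within the data shown here, only one measured step bears on this change: a number no lower from compound 1 to compound 2 (the limit leaves the size open). It gives a direction but no size. The sole numeric reference is therefore compound 1 at 100000 nM, and nothing in these data points to a large gain. Only a small move toward a lower number is expected, an estimated at least 1.1-fold lower number from compound 2 to compound 3 (0.04 log units; that floor lies within the scatter). For compound 3 the expected value is an estimated 90000 nM, within a range of 30000 nM to 200000 nM.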

Compound 3, half-maximal inhibitory concentration: > 100000 nM
Compound 3 was reported as a limit; the forecaster's own chance of this, stated with the estimate: 50%; middle value at least 1.1-fold (0.04 log units) from the limit.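

Compound 3 is reported as a limit, > 100000 nM. Methyl in place of hydrogen on a carbonyl carbon, a change the earlier compounds did not cover, gives a number no lower from compound 1 to compound 3 (the limit leaves the size open) in this assay, so acetyl, like cyano, brings no readable gain over the formyl of compound 1 at this place on the chain. The step between the cyano and acetyl compounds cannot be read, because both values are limits: the limit of > 100000 nM in this assay, at which 2 of the 3 values shown sit.

Among these compounds, whether any group on this double-bonded chain carbon can give a clearly lower number than compound 1 at 100000 nM remains open, since that is the only readable value here. The compounds shown also leave open how a carboxylic acid, an amine or a longer chain would behave at this place.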